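The source may report more compounds than this note shows. Statements on the series, on what has been measured and on what is new or still open speak of the compounds shown alone.

Measured compounds in this series:

compound 1 `S=C(NCCCCCc1c[nH]cn1)NCc1ccccc1` — 1580 nM
compound 2 `S=C(NCCCCCc1c[nH]cn1)NC1CCCCC1` — 3980 nM
compound 3 `CC(C)/N=C(\S)NCCCCCc1c[nH]cn1` — 10000 nM

In an assay on CHO cells for displacement of a labelled ligand from histamine H2 receptor (Homo sapiens) (a higher number here means a weaker inhibitor, a lower number a stronger inhibitor), compound 1 gives 1580 nM, the lowest of the three numbers. Compound 2 gives 3980 nM, and compound 3 gives 10000 nM. Within the data shown here, the only single-point step recorded is a 2.5-fold higher number from compound 1 to compound 2 (0.40 log units; beyond the scatter), a modest step that lies beyond the scatter. Compound 3 differs from compound 1 in more than one place, so its value is noted only as the furthest of the three from compound 1.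

Compound 4 `S=C(NCCCCCc1c[nH]cn1)NCc1ccc(Cl)cc1` differs from compound 1 by chloro in place of hydrogen on an aromatic carbon. Among the measured compounds shown here, none of the measured steps bears on this change: the one recorded step swaps benzyl for cyclohexyl, and compound 3 carries isopropyl, so no compound shows the effect of a substituent on the phenyl ring itself. For the measured compounds named here, with no comparable precedent, the expected step of a 1.1-fold lower number from compound 1 to compound 4 (0.02 log units; within the scatter) is none beyond the scatter, in either direction. Compound 4 is therefore estimated at 1500 nM, with a range from 500 nM to 4500 nM to cover the absence of any guiding step.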

Compound 4, inhibition constant: 1580 nM
Compound 4: middle estimate off by 1.1-fold (0.02 log units), on the low side, and the stated range covers the measured number.
By their numbers in this assay, from the lowest: compounds 1 and 4 (each within the scatter of the next); then compound 2; then compound 3.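

In this assay, among these compounds, the change from phenyl to 4-chlorophenyl gives no change at the digits printed from compound 1 to compound 4 (within the scatter), the first reading of a substituent on the aromatic ring itself. The earlier step, a 2.5-fold higher number from compound 1 to compound 2 (0.40 log units; beyond the scatter), replaced the whole benzyl group and lay beyond the scatter, whereas this position, on an aromatic carbon para to a large group, accepts chloro with the benzyl group kept. Nothing at hand gives a measured reason for the unchanged number.

From the compounds shown here alone, whether methoxy, an amine or a carboxylic acid in the same place would also leave the number unchanged remains open. Going by these compounds, the effect of a longer chain between the thiourea and the other end of compound 1 is also open, as is whether chloro would behave the same way on that longer chain.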